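Working notes on chain variants of the shared core

A few compounds are considered here, and "the series" means these few. Any claim that something is new, unique, unknown or untested is made for them only; others in the source may bear on it.

Compound 3 `O=C(O)CCc1ccncc1-c1ccc2ccccc2c1` gives 101% in an assay on a protein complex for inhibition of CDK8/Cyclin C (Homo sapiens), with a stated time of 1 h, tested at 10 uM; a lower number here means less inhibition, a higher number more inhibition at the concentration tested (going by the name of the read-out). That number is the second highest of the three measured: compound 2 `NC(=O)/C=C/c1ccncc1-c1ccc2ccccc2c1` gives 102%, within the scatter of compound 3, while compound 1 `O=C(O)COc1ccncc1-c1ccc2ccccc2c1` gives 16%, far lower. Compound 4 `O=C(/C=C/c1ccncc1-c1ccc2ccccc2c1)NC1CC1` is not yet measured; it differs from compound 3 as follows: 2-(cyclopropylcarbamoyl)ethenyl in place of 2-carboxyethyl on an aromatic carbon. The step that bears most on this change is a number 1 percentage points lower from compound 2 to compound 3 (within the scatter), which was within the scatter; the step of a number 85 percentage points higher from compound 1 to compound 3 (beyond the scatter) was large but concerns the carboxymethoxy group, absent here. Because compound 2 with its 2-carbamoylethenyl chain gives 102%, a near-full read-out is expected for the cyclopropyl amide too. The estimated step is a number 6 percentage points lower from compound 3 to compound 4 (within the scatter). Compound 4 is therefore expected at 95%, between 70% and 105%.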

Compound 4, a percentage reported as inhibition, at one concentration (the size of the read-out at that concentration, not a potency): 102%
Compound 4: middle estimate off by 7 percentage points, on the low side; low and high end bracket the measured number.
By their numbers in this assay, from the lowest: compound 1; then compounds 3, 2 and 4 (each within the scatter of the next).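

Opposite the ring nitrogen, the amide-type nitrogen of the chain accepts a cyclopropyl group in this assay (no change at the digits printed from compound 2 to compound 4 (within the scatter)). The 2-(cyclopropylcarbamoyl)ethenyl chain also stands level with the 2-carboxyethyl chain (a number 1 percentage points higher from compound 3 to compound 4 (within the scatter)), and the gap to the carboxymethoxy group stays wide (a number 86 percentage points higher from compound 1 to compound 4 (beyond the scatter)). No measurement at hand accounts for these steps.

As far as these compounds go, whether a morpholine amide or a longer chain on the amide-type nitrogen keeps this read-out stays open. At one concentration, these readings do not separate compound 2, compound 3 and compound 4 in the size of the effect.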